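Ester hydrolysis on the amide-linked piperidine series

The source may hold more compounds than are shown below. What is called first, only, known or untested is meant among the compounds shown, and "the series" means these compounds.

Two compounds of this series have numbers in a functional assay on HEK293 cells for antagonist activity at 5-hydroxytryptamine receptor 4 (Homo sapiens), with a stated time of 20 min; a higher number here means a more potent compound, by a factor of ten per unit of this negative logarithm, a lower number a less potent compound. Compound 1 `O=C(O)CCCN1CCC(COC(=O)c2c[nH]c3ccccc23)CC1` gives 8.16 there. Compound 2 `CCOC(=O)CCCN1CCC(CNC(=O)c2c[nH]c3ccccc23)CC1` gives 5.84 in this assay, the lowest of the two values, with compound 1 standing higher by a gap beyond the scatter. Among the measured compounds shown here, compound 1 and compound 2 differ in more than one place, so no single counted step connects them; their two values are all that can be read.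

Compound 3 `O=C(O)CCCN1CCC(CNC(=O)c2c[nH]c3ccccc23)CC1` is not yet measured. It differs from compound 2 in one place: hydrogen in place of ethyl on an oxygen next to a carbonyl group. For the measured compounds named here, no measured pair shows this exact change on this core. The closest pointer is compound 1, which carries the same carboxy terminus and gives 8.16, while the ethyl ester compound 2 stays at 5.84. A rise beyond the scatter is therefore expected from compound 2 to compound 3, estimated at a number 1.66 log units higher from compound 2 to compound 3 (beyond the scatter) in this assay. For compound 3 the expected value in this assay is 7.5, with a range from 6.4 to 8.5.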

Compound 3, negative logarithm of the antagonist equilibrium constant: 4.62
Beside the measured number, compound 3's estimate is 2.88 log units above it; the measured number lies below the stated range.
By their numbers in this assay, from the lowest: compound 3; then compound 2; then compound 1.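

In this assay, hydrogen in place of ethyl on an oxygen next to a carbonyl group gives a number 1.22 log units lower from compound 2 to compound 3 (beyond the scatter), a large step, so on this amide-linked core the carboxy terminus stands lower than the ethoxycarbonyl terminus. The carboxy terminus thus does not bring a high number on its own: compound 1 gives 8.16 and compound 3 gives 4.62 with the same terminus, and these two structures differ in one place, an ester link in compound 1 and an amide link in compound 3. Nothing at hand bears on why this step runs downward.

Still open, as far as these compounds go, is whether ethoxycarbonyl to carboxy runs the same way on the core of compound 1, a question that would take the ethyl ester of that compound to answer. Also open, from the compounds shown here alone, is how a methyl ester, a primary amide or a longer chain ending in a carboxylic acid would read in this assay on the amide-linked core.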